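The compounds below may be only part of what the source reports. "The series", "measured", "known", "first", "only" and "open" are said of these compounds alone.

Three compounds share one core and differ only in the tail that sits at the end of a saturated chain. For the measured compounds named here, compound 1 `N#CNC(=N)NCCCCCn1nc(-c2ccccc2)ccc1=O` is the first of them. In a functional assay on the whole organism (stomach) with Rattus norvegicus as the target (a higher number here means that more compound is needed for the effect, a lower number that less compound is needed), compound 1 gives > 100 mg/kg, and this is a limit of the assay rather than a number. Compound 2 `CC/N=C(\S)NCCCCCn1nc(-c2ccccc2)ccc1=O` gives 51.8 mg/kg in this assay. Compound 3 `C=CCNC(=S)NCCCCn1nc(-c2ccccc2)ccc1=O` gives > 100 mg/kg in this assay, which again is a limit and not a measured number. Compound 3 thus stands at the edge of what this assay reports, the point at which most of the known values sit (the limit of > 100 mg/kg in this assay, at which 2 of the 3 values shown sit).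

The measured steps are few. A swap on an amine nitrogen gave an at least 1.9-fold lower number from compound 1 to compound 2 (0.28 log units; that floor lies within the scatter). A swap further along the chain gave an at least 1.9-fold higher number from compound 2 to compound 3 (0.28 log units; that floor lies within the scatter), while a step that the two limits leave unreadable from compound 1 to compound 3 cannot be read at all.

Compound 4 `CC(C)C/N=C(\S)NCCCCn1nc(-c2ccccc2)ccc1=O` differs from compound 3 by a group of 7 heavy atoms (5 carbon, 1 nitrogen, 1 sulfur; no ring) in place of a group of 6 heavy atoms (4 carbon, 1 nitrogen, 1 sulfur; no ring), on an amine nitrogen. Going by the values given here, the only measured step at an amine nitrogen, an at least 1.9-fold lower number from compound 1 to compound 2 (0.28 log units; that floor lies within the scatter), reached a floor that lies within the scatter, so no step beyond the scatter is expected here, an at least 1.4-fold lower number from compound 3 to compound 4 (0.15 log units; that floor lies within the scatter). Compound 4 is therefore expected to give about 70 mg/kg, somewhere between 25 mg/kg and 200 mg/kg.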

Compound 4, dose for half-maximal effect: > 100 mg/kg
Compound 4: no number, only a limit; the forecaster's own chance of this, stated with the estimate: 45%; middle value at least 1.4-fold (0.15 log units) from the limit.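

On an amine nitrogen, the group of 7 heavy atoms in place of the group of 6 heavy atoms still leaves no measured number in this assay, so this change gives no size to read at this position: the limit of > 100 mg/kg in this assay, at which 3 of the 4 values shown sit. The steps from compound 3 and from compound 1 to compound 4 cannot be read, since both ends of each are limits. Compound 2 remains the only measured number in the set, and the comparison with it gives an at least 1.9-fold higher number from compound 2 to compound 4 (0.28 log units; that floor lies within the scatter), so even this step is not shown to exceed the scatter, although the true gap could be larger than this floor.

As far as these compounds go, it remains open how far past the limit compound 3 and compound 4 lie, and therefore whether the change on the amine nitrogen does anything at all to the dose needed. From the compounds shown here alone, it is also open whether a different group on that nitrogen, such as a carboxylic acid or a simple amine, or a longer chain carrying the group of compound 4, would give a number that can be compared with compound 2.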